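This account rests on a few compounds, and the source may have more. Where it says the series, first, only, none or still open, it means among the compounds named here.

Measured in a functional assay on HL-60 cells (Homo sapiens) for cytotoxicity, read by ELISA, with a stated time of 2 days; on this read-out lower numbers stand for stronger inhibition and higher numbers for weaker inhibition:

Compound 1 `Oc1cccc(-c2cc(-c3ccccc3)cc(-c3cccs3)n2)c1`: 14100 nM
Compound 2 `Oc1cccc(-c2cc(-c3ccccc3)cc(-c3ccsc3)n2)c1`: 10300 nM
Compound 3 `Oc1cccc(-c2cc(-c3ccccc3)nc(-c3cccs3)c2)c1`: 18900 nM

All three measured numbers sit in the same region, and every pairwise gap among them is within the usual scatter, so no ordering among compound 1, compound 2 and compound 3 is claimed here.

Compound 1 and compound 2 share a core and differ only in the change (thiophen-3-yl in place of thiophen-2-yl on an aromatic carbon). That change gave a 1.4-fold lower number from compound 1 to compound 2 (0.14 log units; within the scatter), a step that is within the scatter.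

Compound 3 carries the same two aryl groups on a different arrangement of the core; how the core of compound 3 differs from that of compound 1 is not broken down here.

Compound 4 `Oc1cccc(-c2cc(-c3ccccc3)nc(-c3ccsc3)c2)c1` is not yet measured in this assay. It stands to compound 3 exactly as compound 2 stands to compound 1: the change is thiophen-3-yl in place of thiophen-2-yl on an aromatic carbon, and its surroundings are the same as in the earlier pair. Because a 1.4-fold lower number from compound 1 to compound 2 (0.14 log units; within the scatter) was within the scatter, the step from compound 3 to compound 4 is expected to be of the same small size, estimated as a 1.4-fold lower number from compound 3 to compound 4 (0.13 log units; within the scatter). On that basis compound 4 is expected to give about 14000 nM in this assay, with an expected range from 7000 nM to 28000 nM; this rests on a single earlier instance of the change, so the range is kept wide.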

Compound 4, half-maximal inhibitory concentration: 12000 nM
Estimate against measurement, compound 4: 1.2-fold (0.07 log units) above, within the range that was stated.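

In this assay, thiophen-3-yl in place of thiophen-2-yl on an aromatic carbon gave a 1.6-fold lower number from compound 3 to compound 4 (0.20 log units; within the scatter), so on this core too the step is small and lies within the scatter. Set beside the earlier step, the change carries from one core to the other with no difference that can be read: the same change on two cores in this assay, a 1.4-fold lower number (0.14 log units; within the scatter) from compound 1 to compound 2 and a 1.6-fold lower number (0.20 log units; within the scatter) from compound 3 to compound 4, 1.2-fold (0.06 log units) apart, within the scatter of two such steps
This shows only that, on these two cores, exchanging one thiophene attachment for the other leaves the number within the scatter; it does not show that either attachment is preferred, and two pairs say nothing about how the same change would behave on any further core.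

All the compounds shown carry the same 3-hydroxyphenyl and phenyl groups and differ only in the thiophene attachment and the arrangement of the core, so the response to a truly different group remains open, for instance an amine, a carboxylic acid or a furan-2-yl in the place held by the thiophene. Also open, on these data alone, is whether a methoxy group in place of the hydroxy group of the 3-hydroxyphenyl would give a step beyond the scatter in this assay.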